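The source may report more compounds than this note shows. Statements on the series, on what has been measured and on what is new or still open speak of the compounds shown alone.

Compound 1 `Cc1ccc(NC(=O)c2cccc(C(F)(F)F)c2)cc1N1Cc2cnc(O[C@H]3CCN(C(=O)OC(C)(C)C)C3)nc2N(C)C1=O` is tested in an ADME assay on BaF3 cells (Mus musculus) for antiproliferative activity, read by CellTiter-Glo and CCK-8 assay, with a stated time of 72 h; on this read-out lower numbers stand for stronger inhibition of growth and higher numbers for weaker inhibition of growth. In this assay, going by the values given here, compound 1 gives 8380 nM, the only number that has been measured so far. Compound 2 `Cc1ccc(Nc2ncc3c(n2)N(C)C(=O)N(c2cc(NC(=O)c4cccc(-c5ccccc5)c4)ccc2C)C3)cc1N` belongs to the same set. In this assay compound 2 gives > 10000 nM, which is a limit of the assay rather than a number (the limit of > 10000 nM in this assay, at which 1 of the 2 values shown sits). Among the compounds with values here, no step between two measured compounds that differ in one place is available, so compound 1 is the only anchor. Compound 3 `Cc1ccc(NC(=O)c2cccc(C(F)(F)F)c2)cc1N1Cc2cnc(OC3CCNCC3)nc2N(C)C1=O` has not yet been measured. It differs from compound 1 by piperidin-4-yl in place of 1-(tert-butoxycarbonyl)pyrrolidin-3-yl on an oxygen on an aromatic ring, in words: piperidin-4-yl in place of 1-(tert-butoxycarbonyl)pyrrolidin-3-yl on an oxygen on an aromatic ring. Within the data shown here, with no measured step to lean on, a modest change toward stronger inhibition is expected, though it may well stay within the scatter. Compound 3 is expected to give 5000 nM, within a range from 1500 nM to 15000 nM. That expectation corresponds to the step of a 1.7-fold lower number from compound 1 to compound 3 (0.22 log units; within the scatter).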

Compound 3, concentration for 50% growth inhibition: > 10000 nM
Compound 3: no number, only a limit (the forecaster's own chance of this, stated with the estimate: 25%); at least 2.0-fold (0.30 log units) between middle value and limit.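

In this assay compound 3 gives > 10000 nM, which is a limit of the assay and not a number. Placing piperidin-4-yl instead of 1-(tert-butoxycarbonyl)pyrrolidin-3-yl on this oxygen brings no visible gain in growth inhibition, and the change can be read only as a floor, an at least 1.1-fold higher number from compound 1 to compound 3 (0.07 log units; that floor lies within the scatter). Whether the true gap goes beyond the usual scatter cannot be told from this result, and the values shown increasingly stop at the same ceiling: the limit of > 10000 nM in this assay, at which 2 of the 3 values shown sit.

This change alters the ring size and removes the tert-butoxycarbonyl group at once, so a piperidin-4-yl that keeps tert-butoxycarbonyl, or a pyrrolidin-3-yl without it, would be needed to separate the two. Also open, going by these compounds, is how a small group such as methyl on this oxygen would behave.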